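The compounds below may be only part of what the source reports. "The series", "measured", "known", "first", "only" and "open" are said of these compounds alone.

Compound 3 `Cc1nn(-c2ccccc2)c(Cl)c1/C=N/NC(=O)c1ccccc1` gives 100 mg/kg in a functional assay on the whole organism (strain albino) with Mus musculus as the target, with a stated time of 30 min (a higher number here means that more compound is needed for the effect, a lower number that less compound is needed), the lowest of the two numbers recorded in this assay. For the measured compounds named here, compound 1 `Cc1ccc(C(=O)N/N=C/c2c(C)nn(-c3ccccc3)c2Cl)cc1` gives 300 mg/kg in this assay, and the single one-place step among the measured compounds is a 3.0-fold lower number from compound 1 to compound 3 (0.48 log units; beyond the scatter), the difference being hydrogen in place of methyl on an aromatic carbon. Compound 2 `COc1ccc(C(=O)N/N=C/c2c(C)nn(-c3ccccc3)c2Cl)cc1` is recorded as "not active" (no number reported) in this assay, with no number behind it.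

Compound 4 `Cc1nn(-c2ccccc2)c(Cl)c1/C=N/NC(=O)COc1ccccc1` differs from compound 3 by phenoxymethyl in place of phenyl on a carbonyl carbon. Going by the values given here, none of the measured steps touches the group on the carbonyl carbon: the step from compound 1 to compound 3 concerns the aromatic substituent only, and the entry for compound 2 carries no number from which a step could be computed. Among the compounds with values here, no measured step therefore bears on this change, and the expectation for compound 4 in this assay rests on compound 3 alone. The working expectation is no step beyond the usual scatter, in either direction, with a wide range to reflect the missing precedent. Compound 4 is estimated at 150 mg/kg, within a range of 60 mg/kg to 500 mg/kg, which would mean an expected step of a 1.5-fold higher number from compound 3 to compound 4 (0.18 log units; within the scatter).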

Compound 4, dose for half-maximal effect: 300 mg/kg
Estimate against measurement, compound 4: 2.0-fold (0.30 log units) below; measured number inside the range.
By their numbers in this assay, from the lowest: compound 3; then compounds 1 and 4 (each within the scatter of the next).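

The group on the carbonyl carbon is now shown to affect the number in this assay: phenoxymethyl in place of phenyl gives a 3.0-fold higher number from compound 3 to compound 4 (0.48 log units; beyond the scatter), the first step read at this place, as the earlier step concerned only a substituent on an aromatic carbon. Phenoxymethyl in place of 4-methylphenyl gives no change at the digits printed from compound 1 to compound 4 (within the scatter), so these two groups are not separated here, while the unsubstituted phenyl of compound 3 stands apart from both; steps to compound 2, which has no number, cannot be read. Nothing measured on hand accounts for either step.

The compounds shown do not separate the oxygen of phenoxymethyl from its added carbon, and a benzyl group on the carbonyl carbon would address that. As far as these compounds go, whether any group at this place improves on compound 3, at 100 mg/kg, also stays open; a methyl group or an aliphatic amine on the carbonyl carbon would speak to it.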